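From Isopropyl to Bromo on the Sulfonyl Aryl Ring

The source may report more compounds than this note shows. Statements on the series, on what has been measured and on what is new or still open speak of the compounds shown alone.

Compound 2 `Cc1ccc(-c2c(NS(=O)(=O)c3ccc(C(C)C)cc3)ncnc2OCCOc2ncc(Br)cn2)cc1` gives 0.16 nM in an assay on cells (Endothelial cell) for binding affinity to Endothelin-1 receptor (Sus scrofa) (on this read-out lower numbers stand for stronger inhibition and higher numbers for weaker inhibition), the only number shown in this series. Its neighbour compound 1 `CCC(C)(C)c1ccc(S(=O)(=O)Nc2ncnc(OCCOc3ncc(Br)cn3)c2-c2ccc(C)cc2)cc1` reaches only a limit in this assay, < 0.001 nM. The step of an at least 160-fold higher number from compound 1 to compound 2 (2.20 log units; beyond the scatter) rests on that limit of < 0.001 nM in this assay, at which 1 of the 2 values shown sits, and shows how strongly the number moves when the group on this ring shrinks. Compound 3 `Cc1ccc(-c2c(NS(=O)(=O)c3ccc(Br)cc3)ncnc2OCCOc2ncc(Br)cn2)cc1` carries bromo in place of isopropyl on an aromatic carbon. Because an at least 160-fold higher number from compound 1 to compound 2 (2.20 log units; beyond the scatter) was large for a smaller group at the same place, compound 3 is expected to come out weaker, estimated at 1 nM with a range from 0.2 nM to 10 nM, a step of a 6.3-fold higher number from compound 2 to compound 3 (0.80 log units; beyond the scatter).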

Compound 3, half-maximal inhibitory concentration: 2.8 nM
Compound 3: the middle estimate sits 2.8-fold (0.45 log units) below what was measured; the range from low to high includes it.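

Earlier, only a change between alkyl groups had been seen at this place; the first non-alkyl group, bromo, gives an 18-fold higher number from compound 2 to compound 3 (1.24 log units; beyond the scatter). Across the three compounds the number rises from 1,1-dimethylpropyl through isopropyl to bromo, and the whole span is an at least 2800-fold higher number from compound 1 to compound 3 (3.44 log units; beyond the scatter). The size of that span is not exact, since compound 1 gives only a limit: the limit of < 0.001 nM in this assay, at which 1 of the 3 values shown sits.

The compounds shown leave open whether the rise follows the size of the group or the change from an alkyl group to a halogen. A methoxy group, a trifluoromethyl group or a longer alkyl chain here could separate the two.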